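Ring stereochemistry in a tri-benzylated propyl sugar series

The compounds below may be only part of what the source reports. "The series", "measured", "known", "first", "only" and "open" are said of these compounds alone.

Measured so far:
- compound 1 `CCC[C@@H]1O[C@H](COCc2ccccc2)[C@H](OCc2ccccc2)[C@H](OCc2ccccc2)[C@H]1O`: "not active" (no number reported)
- compound 2 `CCC[C@@H]1O[C@H](CO)[C@@H](O)[C@H](O)[C@H]1O`: "not active" (no number reported)
- compound 3 `CC(C)C[C@@H]1O[C@H](COCc2ccccc2)[C@@H](OCc2ccccc2)[C@H](OCc2ccccc2)[C@H]1O`: 8500 nM

In a functional assay on HL-60 cells (Homo sapiens) for antiproliferative activity, read by MTT assay (a lower number here means a stronger inhibitor, a higher number a weaker inhibitor), compound 1 gives "not active" (no number reported), so no number is available for it. Compound 2, carrying free hydroxyls in place of the benzyl ethers, gives "not active" (no number reported) in this assay. Only compound 3, with a branched side chain and a different ring configuration, gives a number, 8500 nM in this assay, and compound 3 is thus the only entry with measurable activity.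

Compound 4 `CCC[C@H]1O[C@H](COCc2ccccc2)[C@@H](OCc2ccccc2)[C@H](OCc2ccccc2)[C@H]1O` is the next candidate. Its relation to compound 1 is the two compounds have the same atoms and bonds and differ only in configuration as drawn: 2 of 5 stereo elements differ; a stereocentre at a saturated ring carbon is drawn S in compound 1 and R in compound 4; a stereocentre at a saturated ring carbon is drawn S in compound 1 and R in compound 4. Within the data shown here, no measured pair in the set isolates such a configurational change, so the size and direction of the step from compound 1 to compound 4 in this assay cannot be read from the data; a shift from no activity to a measurable but weak value is possible, as is no change at all, given that compound 3 shows activity only in the micromolar region. Compound 4 is expected to give about 20000 nM in this assay, within a range of 5000 nM to 80000 nM, with a sizeable chance that only an inactive result is returned.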

Compound 4, half-maximal inhibitory concentration: 28200 nM
Compound 4: middle estimate off by 1.4-fold (0.15 log units), on the low side, and the stated range covers the measured number.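

In this assay compound 1 gives "not active" (no number reported) and compound 4 gives 28200 nM, so no step can be read between them. The compounds shown leave open whether one or both changed stereocentres account for the number seen for compound 4, given this single difference: the fact that compounds 1 and 4 differ only in the configuration as drawn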